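Chloro for Methoxy on the Shared Core: Expected Potency

The compounds below may be only part of what the source reports. "The series", "measured", "known", "first", "only" and "open" are said of these compounds alone.

Measured compounds:
compound 1, `COc1nc(Cl)nc(C)c1CCO`: > 100000 nM
compound 2, `COc1nc(C)c(CCF)c(OC)n1`: > 100000 nM

Both were tested in a functional assay on SW-620 cells (Homo sapiens) for antiproliferative activity, read by MTT assay, with a stated time of 24 h; on this read-out lower numbers stand for stronger inhibition and higher numbers for weaker inhibition. For compound 1 the value is a limit of the assay, not a number. For compound 2 the value is also a limit. For the measured compounds named here, compound 2 thus stands at the limit, together with the only other value shown (the limit of > 100000 nM in this assay, at which 2 of the 2 values shown sit). Compound 3, `COc1nc(Cl)nc(C)c1CCF`, differs from compound 2 by chloro in place of methoxy on an aromatic carbon. No step between measured compounds is shown, so the expectation is no step beyond the scatter, with compound 3 expected to remain at the limit, a step that the limit leaves unreadable from compound 2 to compound 3. Compound 3 is estimated at 150000 nM, between 50000 nM and 500000 nM.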

Compound 3, half-maximal inhibitory concentration: > 100000 nM
Compound 3: only a limit was reported (the forecaster's own chance of this, stated with the estimate: 85%); the middle value is on the limit's open side.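

For the compounds shown here, no step to compound 3 can be read from compound 2 or compound 1, because all three stand at a limit: the limit of > 100000 nM in this assay, at which 3 of the 3 values shown sit. From the compounds shown here alone, whether chloro for methoxy or fluoro for hydroxy changes the activity at all stays open.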